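A few compounds are considered here, and "the series" means these few. Any claim that something is new, unique, unknown or untested is made for them only; others in the source may bear on it.

In a functional assay on the whole organism (strain Hartley) for inhibition, with Cavia porcellus as the target, with stated times of 15 min and 2 min (a higher number here means that more compound is needed for the effect, a lower number that less compound is needed), compound 3 (`CCCCC1([C@H](O)/C=C/C2CCC(=O)[C@@H]2CCCCCCC(=O)O)CCC1`) gives 0.0024 mg/kg, the lowest number of the three, against compound 1 (`CCCCC1([C@H](O)/C=C/C2CCC(=O)[C@@H]2CCCCCC(=O)O)CCC1`) at 0.032 mg/kg and compound 2 (`CCCCC1([C@H](O)/C=C/C2CCC(=O)[C@@H]2CCCCSCC(=O)OCC)CCC1`) at 0.03 mg/kg. Compound 4 (`CCCCC1([C@H](O)/C=C/C2CCC(=O)[C@@H]2CCCCCCCCC(=O)OCC)CCC1`) departs from compound 3 by 2-(ethoxycarbonyl)ethyl in place of carboxy on a saturated chain carbon, six bonds along the chain from a saturated ring carbon, so 2-(ethoxycarbonyl)ethyl stands in place of carboxy. Two large measured steps bear on this change. Carboxymethyl in place of carboxy gave a 13-fold lower number from compound 1 to compound 3 (1.12 log units; beyond the scatter), and 2-carboxyethyl in place of ((ethoxycarbonyl)methyl)sulfanyl gave a 13-fold lower number from compound 2 to compound 3 (1.10 log units; beyond the scatter). Neither matches the change exactly, yet both show how sharply the number responds at this end of the chain. A reversal of similar size is therefore expected, a 10-fold higher number from compound 3 to compound 4 (1.02 log units; beyond the scatter), beyond the scatter. For compound 4 the estimated value is 0.025 mg/kg, with an expected range from 0.005 mg/kg to 0.12 mg/kg.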

Compound 4, dose for half-maximal effect: 6.21 mg/kg
Compound 4: middle estimate off by 250-fold (2.40 log units), on the low side; the whole stated range lies below it.
By their numbers in this assay, from the lowest: compound 3; then compounds 2 and 1 (each within the scatter of the next); then compound 4.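

In this assay, among these compounds, this end of the chain proves far less forgiving than the earlier compounds showed, with a 2600-fold higher number from compound 3 to compound 4 (3.41 log units; beyond the scatter), the largest step in the set. The ethyl ester as such does not settle the matter: two ethyl esters are separated by a 210-fold higher number from compound 2 to compound 4 (2.32 log units; beyond the scatter). The shorter acid also stands well apart, with a 190-fold higher number from compound 1 to compound 4 (2.29 log units; beyond the scatter).

Nothing given here explains this loss. As far as these compounds go, it stays open whether the chain length or the ester carries it, which a free carboxylic acid on the longer chain would help to separate.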